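The source may hold more compounds than are shown below. What is called first, only, known or untested is meant among the compounds shown, and "the series" means these compounds.

Measured compounds, with their values in a functional assay on CWR22R cells (Homo sapiens) for antiproliferative activity, read by propidium iodide staining, with a stated time of 96 h; a higher number here means a weaker inhibitor, a lower number a stronger inhibitor:

Compound 1, `CC(O)(CSc1cccc(S(F)(F)(F)(F)F)c1)C(=O)Nc1ccc(C#N)c(C(F)(F)F)c1`: 20400 nM
Compound 2, `CC(O)(CSc1cccc(S(F)(F)(F)(F)F)c1)C(=O)Nc1ccc([N+](=O)[O-])c(C(F)(F)F)c1`: 8800 nM
Compound 3, `CC(O)(CSc1cccc(S(F)(F)(F)(F)F)c1)C(=O)Nc1ccc(C#N)cc1C(F)(F)F`: 21600 nM

Compounds 1 and 2 share one core and differ in a single place: nitro in place of cyano on an aromatic carbon. This change gave a 2.3-fold lower number from compound 1 to compound 2 (0.37 log units; beyond the scatter), a step that lies beyond the usual scatter but is modest in size. Compound 3 has the same atoms as compound 1 joined differently; the difference between the two cores is not broken down here. In this assay compound 3 and compound 1 lie within the scatter of each other, and compound 3 stands apart from compound 2 by a margin beyond the scatter.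

Compound 4, `CC(O)(CSc1cccc(S(F)(F)(F)(F)F)c1)C(=O)Nc1ccc([N+](=O)[O-])cc1C(F)(F)F`, has not yet been measured. Compared with compound 3 it differs as follows: nitro in place of cyano on an aromatic carbon. Among the measured compounds shown here, this is the same kind of change as the one from compound 1 to compound 2, but the surroundings are not identical: in compound 2 the nitro sits ortho to a trifluoromethyl group, in compound 4 it sits meta to a trifluoromethyl group, in both cases para to a large group.

Compound 4 is expected to give about 10000 nM in this assay. For the measured compounds named here, the expected step from compound 3 is estimated as a 2.2-fold lower number from compound 3 to compound 4 (0.33 log units; beyond the scatter), resting on the single earlier instance, a 2.3-fold lower number from compound 1 to compound 2 (0.37 log units; beyond the scatter), with added uncertainty for the different placement. The expected range for compound 4 runs from 4500 nM to 24000 nM.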

Compound 4, half-maximal inhibitory concentration: 17500 nM
Beside the measured number, compound 4's estimate is 1.8-fold (0.24 log units) below it, within the range that was stated.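

In this assay, nitro in place of cyano on an aromatic carbon, here meta to a trifluoromethyl group and para to a large group, gave a 1.2-fold lower number from compound 3 to compound 4 (0.09 log units; within the scatter), a step that by itself cannot be told from no change. Set beside its earlier counterpart, however, this step does not show that the change behaves differently on the two cores: the same change on two cores in this assay, a 2.3-fold lower number (0.37 log units; beyond the scatter) from compound 1 to compound 2 and a 1.2-fold lower number (0.09 log units; within the scatter) from compound 3 to compound 4, 1.9-fold (0.27 log units) apart, within the scatter of two such steps. Among the compounds shown here, the two instances are therefore compatible with a change that carries over between these cores, but they do not establish this, since only one of the two steps lies beyond the scatter and two pairs cannot fix the size of the step or show whether the placement of the trifluoromethyl group has any bearing on it.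

The compounds shown leave open how a chloro group, an amine or a carboxylic acid would compare with cyano and nitro at this aromatic carbon. They also leave open whether the step would look the same with a sulfone in place of the thioether sulfur, as all four compounds keep that part of the molecule unchanged.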